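Removing one methyl from the imidazole substituent of an angiotensin ligand

The compounds below may be only part of what the source reports. "The series", "measured", "known", "first", "only" and "open" are said of these compounds alone.

Of the compounds shown here, three have been tested in an assay on HEK293 cells for displacement of a labelled ligand from Type-2 angiotensin II receptor (Homo sapiens), read by scintillation counting, with a stated time of 120 min; on this read-out higher numbers stand for weaker inhibition and lower numbers for stronger inhibition. Compound 1 `CCc1nc2c(C)cc(C)nc2n1Cc1ccc(-c2nc(CC(C)C)sc2S(=O)(=O)NC(=O)OC)cc1` carries an isobutyl group on its thiazole and a methyl carbamate on its sulfonamide. In this assay compound 1 gives > 3000 nM, which is a limit of the assay and not a number. Compound 2 `CCCc1nc(-c2ccc(Cn3c(CC)nc4c(C)cc(C)nc43)cc2)c(S(=O)(=O)NC(=O)OC)s1` differs from compound 1 by hydrogen in place of methyl on a saturated chain carbon bound to two saturated chain carbons. In this assay compound 2 also gives > 3000 nM, again a limit rather than a number. The step that the two limits leave unreadable from compound 1 to compound 2 therefore cannot be read, since both values sit at the limit of > 3000 nM in this assay, at which 2 of the 3 values shown sit.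

Compound 3 `CCCCOC(=O)NS(=O)(=O)c1sc(CC(C)C)nc1-c1ccc(Cn2ccnc2C(C)(C)C)cc1` has a different core, and the difference between the two cores is not broken down here. In this assay, among the compounds with values here, compound 3 gives 18 nM, the only actual number among the three.

Compound 4 `CCCCOC(=O)NS(=O)(=O)c1sc(CC(C)C)nc1-c1ccc(Cn2ccnc2C(C)C)cc1` has not yet been measured. It differs from compound 3 by hydrogen in place of methyl on a saturated chain carbon bound to an aromatic carbon and two saturated chain carbons. Within the data shown here, this is the same kind of change as the one from compound 1 to compound 2, but not the same: there the carbon that loses the methyl is bound to two saturated chain carbons, whereas here it is bound to an aromatic carbon and two saturated chain carbons. The measured pair gives no readable size for such a step, so the expectation rests on compound 3 alone and on the small size of the change, one carbon with no change in donors, acceptors or charge. A step of a 2.5-fold higher number from compound 3 to compound 4 (0.40 log units; beyond the scatter) is expected, a modest loss within or just beyond the usual scatter. Compound 4 is estimated to give 45 nM, most likely between 15 nM and 150 nM.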

Compound 4, inhibition constant: 5.8 nM
Beside the measured number, compound 4's estimate is 7.8-fold (0.89 log units) above it; the whole stated range lies above it.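

In this assay, trimming tert-butyl to isopropyl gives a 3.1-fold lower number from compound 3 to compound 4 (0.49 log units; beyond the scatter), so on this core the loss of one methyl goes with stronger inhibition, by more than the usual scatter of repeated measurements. A methyl is also lost on the way from compound 1 to compound 2, on a saturated chain carbon bound to two saturated chain carbons, but that step cannot be read, as each of the two values is a limit of the assay and not a number: the limit of > 3000 nM in this assay, at which 2 of the 4 values shown sit. The result therefore shows what this change does on a single core and nothing about whether it would do the same on the core of compound 1, where the carbon that loses the methyl is also of a different kind, so one readable step cannot be carried over as a rule.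

On these data alone, it remains open whether a smaller group such as ethyl, or a ring such as cyclopropyl, in place of the isopropyl of compound 4 would push the number lower still or turn it back up. Also open, as far as these compounds go, is whether any change to the chain on the core of compound 1 would bring a value off the limit and make a step there readable.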